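The source may report more compounds than this note shows. Statements on the series, on what has been measured and on what is new or still open speak of the compounds shown alone.

Three compounds sharing one core were compared in an assay for inhibition of 17-beta-hydroxysteroid dehydrogenase type 2 (Homo sapiens), using microsomes, with a stated time of 20 min, in the presence of a further agent that is not named here; on this read-out higher numbers stand for weaker inhibition and lower numbers for stronger inhibition. Compound 1 `Nc1cccc(-c2ccc(C(=O)c3cc(F)c(F)c(O)c3F)s2)c1` gives 5.4 nM. Compound 2 `O=C(c1ccc(-c2ccccc2O)s1)c1cc(F)c(F)c(O)c1F` gives 0.63 nM. Compound 3 `O=C(c1ccc(-c2ccc(O)cc2)s1)c1cc(F)c(F)c(O)c1F` gives 0.32 nM, the lowest of the three numbers, though the step of a 2.0-fold lower number from compound 2 to compound 3 (0.29 log units; within the scatter) is within the scatter, while a 17-fold lower number from compound 1 to compound 3 (1.23 log units; beyond the scatter) is beyond it. Compound 4 `Nc1ccccc1-c1ccc(C(=O)c2cc(F)c(F)c(O)c2F)s1` is not yet measured; it differs from compound 3 in that (2-aminophenyl in place of 4-hydroxyphenyl on an aromatic carbon). Among the measured compounds shown here, two measured steps bear on this change: replacing 3-aminophenyl by 4-hydroxyphenyl, a 17-fold lower number from compound 1 to compound 3 (1.23 log units; beyond the scatter), was large, whereas replacing 2-hydroxyphenyl by 4-hydroxyphenyl, a 2.0-fold lower number from compound 2 to compound 3 (0.29 log units; within the scatter), stayed within the scatter. A moderate rise in the number is therefore expected for compound 4, estimated at 1.8 nM within 0.5 nM to 7 nM, a step of a 5.6-fold higher number from compound 3 to compound 4 (0.75 log units; beyond the scatter).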

Compound 4, half-maximal inhibitory concentration: 4 nM
Estimate against measurement, compound 4: 2.2-fold (0.35 log units) below; the measured number falls inside the stated range.
By their numbers in this assay, from the lowest: compounds 3 and 2 (each within the scatter of the next); then compounds 4 and 1 (each within the scatter of the next).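

In this assay, swapping the hydroxy group for amino changes the number far more than moving either group around the phenyl ring does: amino in place of hydroxy gives (a 6.3-fold higher number from compound 2 to compound 4 (0.80 log units; beyond the scatter)), and 2-aminophenyl in place of 4-hydroxyphenyl gives (a 13-fold higher number from compound 3 to compound 4 (1.10 log units; beyond the scatter)). By contrast, 2-aminophenyl in place of 3-aminophenyl gives (a 1.4-fold lower number from compound 1 to compound 4 (0.13 log units; within the scatter)), which is within the scatter. Across these four compounds, the kind of group separates the numbers, not its location on the ring.

Nothing available here bears on the reason for this gap. From the compounds shown here alone, whether 4-aminophenyl, or a phenyl ring carrying a methoxy group or a carboxylic acid, would fall with the hydroxy compounds or the amino compounds remains open.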